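The source may report more compounds than this note shows. Statements on the series, on what has been measured and on what is new or still open speak of the compounds shown alone.

Three compounds of this series have so far been run in a functional assay on the whole organism for inhibition, with Rattus norvegicus as the target, with a stated time of 60 min, at pH 4.5, at a dose of 20 mg/kg by the oral route; on this read-out higher numbers stand for a stronger effect at the one dose given and lower numbers for a weaker effect. Compound 1 `O=S(=O)(c1ccc(Cl)c(Cl)c1)c1ccc(O)nn1` gives 85%. Compound 2 `O=S(=O)(Cc1cccc(C(F)(F)F)c1)c1ccc(O)nn1` gives 70%. Compound 3 `O=S(=O)(Cc1cccc(F)c1F)c1ccc(O)nn1` gives 51%, the lowest of the three readings; its gap to compound 2 lies beyond the scatter, and its gap to compound 1 lies further beyond it. Among the compounds with values here, no two of these three differ in a single place, so no measured step is available within the set.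

Compound 4 `O=S(=O)(Cc1cccc(C(F)(F)F)c1F)c1ccc(O)nn1` has not yet been measured. It differs from compound 3 by trifluoromethyl in place of fluoro on an aromatic carbon. Within the data shown here, the only guide in the data is compound 2, which also carries a trifluoromethyl group and gives 70%, well above compound 3. On that basis the expected step is a number 11 percentage points higher from compound 3 to compound 4 (beyond the scatter), upward, of a size somewhat beyond the scatter but short of the reading of compound 2. For compound 4 the estimate is 62%, with a range from 45% to 80%.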

Compound 4, a percentage reported as inhibition, in the whole organism at one dose (the size of the read-out at that dose, not a potency): 56%
Estimate against measurement, compound 4: 6 percentage points above, within the range that was stated.
By their numbers in this assay, from the lowest: compounds 3 and 4 (each within the scatter of the next); then compound 2; then compound 1.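

In this assay, trifluoromethyl in place of fluoro on an aromatic carbon, ortho to a fluoro group, gives a number 5 percentage points higher from compound 3 to compound 4 (within the scatter) and so does not separate the two groups at this position. Fluoro in place of hydrogen on an aromatic carbon gives a number 14 percentage points lower from compound 2 to compound 4 (beyond the scatter) and is the first change in the series shown to move the reading beyond the scatter, though the step is modest and rests on this single pair. Nothing at hand bears on why either step has the size it has.

As far as these compounds go, whether a nitrile or a methoxy group on the same aromatic carbon would read apart from fluoro and trifluoromethyl remains open. From the compounds shown here alone, with one dose and one time point, it also remains open whether these two steps would hold at other doses.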